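Halogen changes on the benzyl group: compound 1 to compound 4

The source may hold more compounds than are shown below. What is called first, only, known or untested is meant among the compounds shown, and "the series" means these compounds.

In a functional assay on MCF7 cells (Homo sapiens) for inhibition, read by MTT assay, with a stated time of 48 h (a lower number here means a stronger inhibitor, a higher number a weaker inhibitor), compound 1 `Clc1ccccc1CSc1nnc(-c2ccncc2)n1-c1ccccc1` gives 18100 nM. Compound 2 `Clc1cccc(CSc2nnc(-c3ccncc3)n2-c2ccccc2)c1` gives 10500 nM. Compound 3 `Brc1cccc(CSc2nnc(-c3ccncc3)n2-c2ccccc2)c1` gives 10000 nM. Compound 1 is therefore not separated from either of the other two measured compounds, and all three values lie within the scatter of one another.

Compound 4 `Fc1ccc(CSc2nnc(-c3ccncc3)n2-c2ccccc2)c(F)c1` has not yet been measured. It carries 2,4-difluorophenyl in place of 2-chlorophenyl on a saturated chain carbon bound to a sulfur.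

Within the data shown here, no measured step makes this exact change. The closest are the two that also replace the 2-chlorophenyl group, a 1.7-fold lower number from compound 1 to compound 2 (0.24 log units; within the scatter) and a 1.8-fold lower number from compound 1 to compound 3 (0.26 log units; within the scatter). The exchange of chloro for bromo, a 1.1-fold lower number from compound 2 to compound 3 (0.02 log units; within the scatter), also bears on it, as a change of halogen alone. All three steps stay within the scatter, so no step beyond the scatter is expected in this assay, and the data give no firm direction. Among the measured compounds shown here, the data hold no fluoro compound, which leaves the range wide.

The estimated change is a 1.3-fold lower number from compound 1 to compound 4 (0.11 log units; within the scatter). For compound 4 the expected value is 14000 nM, with an estimated range of 7000 nM to 28000 nM.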

Compound 4, half-maximal inhibitory concentration: 14100 nM
Compound 4: the middle estimate sits 1.0-fold (0.00 log units) below what was measured; measured number inside the range.
By their numbers in this assay, from the lowest: compounds 3, 2, 4 and 1 (each within the scatter of the next).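

In this assay the first fluoro compound and the first with two halogens on the ring stays within the scatter of every compound before it (a 1.3-fold lower number from compound 1 to compound 4 (0.11 log units; within the scatter); a 1.4-fold higher number from compound 3 to compound 4 (0.15 log units; within the scatter); a 1.3-fold higher number from compound 2 to compound 4 (0.13 log units; within the scatter)). The series at this position on a saturated chain carbon bound to a sulfur now spans chloro, bromo and fluoro, and one halogen or two, without a single step beyond the scatter, so none of the four compounds can be ranked against another. No measured information on these compounds accounts for this flat result, and none bears on it.

As far as these compounds go, whether any group at this position can move the number beyond the scatter stays open, since only halogen-bearing phenyl groups appear here, with nothing to show what an amine, a carboxylic acid or a methoxy group on that ring would do, or a longer chain in place of the benzyl group. Also open, from the compounds shown here alone, is whether changes elsewhere on the core of compound 1, such as on the phenyl or the pyridine-bearing side, would do more than this position has so far.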